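The source may hold more compounds than are shown below. What is called first, only, known or untested is meant among the compounds shown, and "the series" means these compounds.

Working notes, measured so far in a physicochemical assay for solubility, read by HPLC, in phosphate buffer, with a stated time of 24 h, at pH 7.4, tested at 100 uM; on this read-out lower numbers stand for lower solubility and higher numbers for higher solubility:
- compound 1 `O=C(CCCCCNc1c(Nc2ccccc2)c(=O)c1=O)NO` gives 47000000 nM here
- compound 2 `O=C(CCCCCNc1c(NCc2ccccc2)c(=O)c1=O)NO` gives 75000000 nM here
- compound 3 `Cc1ccccc1Nc1c(NCCCCCC(=O)NO)c(=O)c1=O` gives 89000000 nM here

Compound 3 sits within the scatter of both other compounds, so its value sets no order in the series. The next step leads to compound 4 `Cc1cccc(Nc2c(NCCCCCC(=O)NO)c(=O)c2=O)c1` and is described as 3-methylphenyl in place of 2-methylphenyl on a nitrogen on an aromatic ring in the comparison of the two structures. In words, it is 3-methylphenyl in place of 2-methylphenyl on a nitrogen on an aromatic ring, and the two compounds have the same atoms, joined differently.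

Within the data shown here, no measured pair exchanges these two groups, so the evidence is indirect. The nearest guide is a 1.9-fold higher number from compound 1 to compound 3 (0.28 log units; within the scatter) for adding the methyl, and a 1.2-fold higher number from compound 2 to compound 3 (0.07 log units; within the scatter) and a 1.6-fold higher number from compound 1 to compound 2 (0.20 log units; within the scatter) show the other changes on that nitrogen. All three stay within the scatter in this assay and none gives a direction to carry over.

The expected move is therefore none beyond the scatter, and the estimate is a 1.3-fold lower number from compound 3 to compound 4 (0.10 log units; within the scatter) as a small step only. For compound 4 the estimated value is 70000000 nM with an expected range from 40000000 nM to 100000000 nM in this series.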

Compound 4, solubility: 79000000 nM
Estimate against measurement, compound 4: 1.1-fold (0.05 log units) below; the measured number falls inside the stated range.
By their numbers in this assay, from the lowest: compounds 1, 2, 4 and 3 (each within the scatter of the next).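

Within this assay, the new pair gives the first direct reading of where the methyl sits on this ring on the nitrogen: 3-methylphenyl in place of 2-methylphenyl gives a 1.1-fold lower number from compound 3 to compound 4 (0.05 log units; within the scatter). Compound 4 also stays close to the other two compounds, with a 1.1-fold higher number from compound 2 to compound 4 (0.02 log units; within the scatter) for 3-methylphenyl in place of benzyl and a 1.7-fold higher number from compound 1 to compound 4 (0.23 log units; within the scatter) for methyl in place of hydrogen on an aromatic carbon, so neither placing of the methyl separates from compound 1 in this read-out, as a 1.9-fold higher number from compound 1 to compound 3 (0.28 log units; within the scatter) had already shown for the 2-methylphenyl compound. No measurement is available that bears on the reason for any of these steps.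

Still open, from the compounds shown here alone, is whether any group on this ring, such as a carboxylic acid or an amine in place of the methyl, would give a step beyond the scatter in this assay. Also open, going by these compounds, is whether a longer chain on the shared core would do so, since all four compounds carry the same chain and every step among them lies within the scatter.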